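Pyridine N-oxide replaces methylpyridine on the bicyclic core

The compounds below may be only part of what the source reports. "The series", "measured", "known", "first", "only" and "open" are said of these compounds alone.

Compound 1 `C[C@@H](O[C@H]1CN2C(=O)C=C(c3ccc(F)cc3)CC2[C@@H]1c1ccc(F)cc1)c1cc(C(F)(F)F)cc(C(F)(F)F)c1`: 2 nM
Compound 2 `Cc1cc(C2=CC(=O)N3C[C@H](O[C@H](C)c4cc(C(F)(F)F)cc(C(F)(F)F)c4)[C@@H](c4ccc(F)cc4)C3C2)ccn1`: 0.51 nM

Within the data shown here, in an assay on CHO cells for displacement of a labelled ligand from Substance-P receptor (Homo sapiens) (on this read-out higher numbers stand for weaker inhibition and lower numbers for stronger inhibition), compound 2 holds the lowest of the two numbers measured so far. Among the measured compounds shown here, the only step known is a 3.9-fold lower number from compound 1 to compound 2 (0.59 log units; beyond the scatter). Compound 3 `C[C@@H](O[C@H]1CN2C(=O)C=C(c3ccc[n+]([O-])c3)CC2[C@@H]1c1ccc(F)cc1)c1cc(C(F)(F)F)cc(C(F)(F)F)c1` differs from compound 2 by a group of 7 heavy atoms (5 carbon, 1 nitrogen, 1 oxygen; one six-membered aromatic ring with 1 hetero atom) in place of a group of 7 heavy atoms (6 carbon, 1 nitrogen; one six-membered aromatic ring with 1 hetero atom), on a double-bonded ring carbon. For the measured compounds named here, no measured step matches this exchange of one aromatic ring for another; a 3.9-fold lower number from compound 1 to compound 2 (0.59 log units; beyond the scatter) bears on the same position but on a different pair of rings, so it gives only a loose guide. Compound 3 is therefore expected to move by a 2.9-fold higher number from compound 2 to compound 3 (0.47 log units; beyond the scatter), a modest weakening that is at most barely beyond the scatter. For compound 3 the estimate in this assay is 1.5 nM, with a range from 0.4 nM to 6 nM.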

Compound 3, half-maximal inhibitory concentration: 0.15 nM
Estimate against measurement, compound 3: 10-fold (1.00 log units) above; the whole stated range lies above it.
By their numbers in this assay, from the lowest: compound 3; then compound 2; then compound 1.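

In this assay, the double-bonded ring carbon takes a further gain beyond the earlier methylpyridine: the pyridine N-oxide gives a 3.4-fold lower number from compound 2 to compound 3 (0.53 log units; beyond the scatter). Against the 4-fluorophenyl group, the same exchange gives a 13-fold lower number from compound 1 to compound 3 (1.12 log units; beyond the scatter), so this single position carries a large range of the read-out. Nothing measured on these compounds accounts for the gain. From the compounds shown here alone, whether it follows from the oxygen or from the loss of the methyl stays open. So does the outcome with an unsubstituted pyridine or an aminopyridine at this place.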